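The source may hold more compounds than are shown below. What is called first, only, known or untested is meant among the compounds shown, and "the series" means these compounds.

Compound 1 `O=C1c2ccccc2C(=O)N1CCOC(=S)N(C(=O)c1ccc([N+](=O)[O-])cc1)c1ccc(Cl)cc1`: > 100000 nM
Compound 2 `Cc1ccc(N(C(=O)c2ccc([N+](=O)[O-])cc2)C(=S)OCCN2C(=O)c3ccccc3C2=O)cc1`: 58000 nM
Compound 3 `O=C1c2ccccc2C(=O)N1CCOC(=S)N(C(=O)c1ccc(Cl)c(Cl)c1)c1ccc(Cl)cc1`: 35000 nM

All three entries come from an ADME assay on MT4 cells (Homo sapiens) for cytotoxicity, read by MTT assay; on this read-out higher numbers stand for lower toxicity in this test and lower numbers for higher toxicity in this test. The entry for compound 1 is a limit of the assay and not a number. Among the two true numbers, compound 2 at 58000 nM and compound 3 at 35000 nM lie within the usual scatter of each other.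

The next compound, compound 4 `Cc1ccc(N(C(=O)c2cccc(Cl)c2Cl)C(=S)OCCN2C(=O)c3ccccc3C2=O)cc1`, differs from compound 2 by 2,3-dichlorophenyl in place of 4-nitrophenyl on a carbonyl carbon. Within the data shown here, the closest precedent is an at least 2.8-fold lower number from compound 1 to compound 3 (0.45 log units; beyond the scatter), where 4-nitrophenyl also leaves and a dichlorophenyl group enters, although with a different pattern. The other measured step, an at least 1.7-fold lower number from compound 1 to compound 2 (0.23 log units; that floor lies within the scatter), changes another part of the molecule and bears on this change only indirectly. A modest step towards a lower number is therefore expected in this assay. The expected step is a 2.3-fold lower number from compound 2 to compound 4 (0.37 log units; beyond the scatter). Compound 4 is estimated at 25000 nM, with an expected range of 9000 nM to 70000 nM.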

Compound 4, half-maximal cytotoxic concentration: 35000 nM
For compound 4 the middle estimate is 1.4-fold (0.15 log units) below the measured one; measured number inside the range.
By their numbers in this assay, from the lowest: compounds 3, 4 and 2 (each within the scatter of the next). At a limit, above all of these: compound 1.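

Among these compounds, the step of a 1.7-fold lower number from compound 2 to compound 4 (0.22 log units; within the scatter) is the first on this carbonyl carbon in this assay with a true number at both ends. On the core of compound 2, this test therefore does not tell 2,3-dichlorophenyl from 4-nitrophenyl, even though the hydrogen-bond acceptors of 4-nitrophenyl are gone. The earlier step at this place, an at least 2.8-fold lower number from compound 1 to compound 3 (0.45 log units; beyond the scatter), brought in 3,4-dichlorophenyl and gives only a floor because it starts from a limit: the limit of > 100000 nM in this assay, at which 1 of the 4 values shown sits.

On these data alone, it remains open whether 2,3-dichlorophenyl and 3,4-dichlorophenyl would differ on one and the same core. As far as these compounds go, it is also open whether an amine or a carboxylic acid on the phenyl ring at this carbonyl carbon would move the number beyond the scatter.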